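Dimethylamino in Place of Phenoxy on a Shared Core

A few compounds are considered here, and "the series" means these few. Any claim that something is new, unique, unknown or untested is made for them only; others in the source may bear on it.

Compound 2, `Cc1cc(O)cc(-c2nn(CC#N)cc2-c2ccnc(-c3ccc(Oc4ccccc4)cc3)c2)c1`, and compound 1, `COc1cc(C)cc(-c2nn(CC#N)cc2-c2ccc(-c3cccc(C(C)=O)c3)nc2)c1`, share a common core and differ in their outer substituents. In a functional assay on MDA-MB-231 cells (Homo sapiens) for cytotoxicity, read by sulforhodamine B assay, with a stated time of 48 h, tested at 0.001 uM (a higher number here means a weaker effect of the compound at the concentration tested, a lower number a stronger effect), compound 1 gives 102%. In this assay compound 2 gives 96%, the lower of the two numbers, although the gap to compound 1 lies within the scatter, so neither compound can be called stronger than the other. Compound 3, `Cc1cc(O)cc(-c2nn(CC#N)cc2-c2ccnc(-c3ccc(N(C)C)cc3)c2)c1`, has not yet been measured; it differs from compound 2 by dimethylamino in place of phenoxy on an aromatic carbon. Among the measured compounds shown here, no step between measured compounds is available to set the size of this change. Both measured values lie close to a null response in this assay, so the step of a number 1 percentage points higher from compound 2 to compound 3 (within the scatter) is expected to stay within the scatter. Compound 3 is therefore estimated at 97%, with a range from 85% to 106%.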

Compound 3, a percentage reported as activity, at one concentration (the size of the read-out at that concentration, not a potency): 99%
Estimate against measurement, compound 3: 2 percentage points below; the measured number falls inside the stated range.
By their numbers in this assay, from the lowest: compounds 2, 3 and 1 (each within the scatter of the next).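

In this assay, dimethylamino in place of phenoxy on the aromatic carbon, para to a large group, gives a number 3 percentage points higher from compound 2 to compound 3 (within the scatter). Among the compounds shown here, this is the first step read at this position, and it shows that exchanging phenoxy, with its six-membered aromatic ring of carbon only, for dimethylamino, which has no ring, leaves the number within the scatter at this single concentration. No measurement is available that bears on this result.

The compounds shown leave open whether a carboxylic acid or a longer amine chain at this position would give a step beyond the scatter. For the compounds shown here, they also leave open whether compound 2 and compound 3 would separate at a higher concentration, since the one tested here gives numbers close to a null response for both.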